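The source may report more compounds than this note shows. Statements on the series, on what has been measured and on what is new or still open speak of the compounds shown alone.

Of the compounds shown here, two have so far been tested in a functional assay on K562 cells (Homo sapiens), read by MTT assay, with a stated time of 72 h; on this read-out higher numbers stand for weaker inhibition and lower numbers for stronger inhibition. Compound 1 `CSc1ncnc2c1c(-c1ccsc1)cn2[C@@H]1O[C@H](CO)[C@@H](O)[C@H]1O` gives > 20000 nM, which is a limit of the assay and not a number. Compound 2 `CNc1ncnc2c1c(-c1cccs1)cn2[C@@H]1O[C@H](CO)[C@@H](O)[C@H]1O` gives > 20000 nM, which is likewise only a limit. Compound 2 thus stands at the limit of > 20000 nM in this assay, at which 2 of the 2 values shown sit, and no measured number lies beside it. Compound 3 `CNc1ncnc2c1c(-c1ccsc1)cn2[C@@H]1O[C@H](CO)[C@@H](O)[C@H]1O` has the same atoms as compound 2, joined differently, with thiophen-3-yl in place of thiophen-2-yl on an aromatic carbon. Among the measured compounds shown here, no measured step in this assay shows what such a change does. With only the limit of > 20000 nM in this assay, at which 2 of the 2 values shown sit, to go on, no shift beyond the usual scatter is expected, in either direction, and the estimated change is a number no higher from compound 2 to compound 3 (the limit leaves the size open). Compound 3 is expected near 20000 nM, with an estimated range from 6000 nM to 40000 nM.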

Compound 3, half-maximal inhibitory concentration: > 20000 nM
Compound 3: only a limit was reported (the forecaster's own chance of this, stated with the estimate: 75%); the middle value lies on the limit itself.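

In this assay compound 3 gives > 20000 nM, which is a limit of the assay and not a number. Its steps from compound 1 and compound 2 therefore cannot be read. The compounds shown leave open whether thiophen-3-yl in place of thiophen-2-yl, or methylamino in place of methylsulfanyl, changes the read-out at all.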